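Swapping One Iodo for Bromo in a Halogenated Series

The compounds below may be only part of what the source reports. "The series", "measured", "known", "first", "only" and "open" are said of these compounds alone.

Measured in a functional assay on DU-145 cells (Homo sapiens) for inhibition, read by trypan blue exclusion, with a stated time of 96 h; a lower number here means a stronger inhibitor of growth, a higher number a weaker inhibitor of growth
Compound 1 `O=C(/C(=C/c1ccc(Br)cc1)S(=O)(=O)Cc1ccc(I)cc1)c1ccc(I)cc1` gives 20000 nM
Compound 2 `O=C(/C(=C/c1ccc(I)cc1)S(=O)(=O)Cc1ccc(I)cc1)c1ccc(Br)cc1` gives 20000 nM

Compound 2 stands level with compound 1 at the digits shown, and the two values lie within the usual scatter of repeated measurements. Neither compound can be placed ahead of the other on these numbers.

Compound 3 `O=C(/C(=C/c1ccc(Br)cc1)S(=O)(=O)Cc1ccc(I)cc1)c1ccc(Br)cc1` comes from compound 2 by a single change, (bromo in place of iodo on an aromatic carbon), which reads as bromo in place of iodo on an aromatic carbon, para to a large group. Cut one bond further out, the same difference is 4-iodophenyl to 4-bromophenyl.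

Within the data shown here, no pair of measured compounds shows this change on its own, so the data offer no direct precedent for its size. In this assay no shift beyond the scatter is expected, in either direction, because compound 1 gives 20000 nM and compound 2 gives 20000 nM with no gap between them. The estimated no change at the digits printed from compound 2 to compound 3 (within the scatter) is therefore expected to be small. For compound 3 the expected growth inhibition value is 20000 nM with an estimated range from 8000 nM to 45000 nM as the likely span.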

Compound 3, concentration for 50% growth inhibition: > 50000 nM
Compound 3 gave a limit, no number (the forecaster's own chance of this, stated with the estimate: 15%); middle value at least 2.5-fold (0.39 log units) away from the limit.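

In this assay compound 3 gives > 50000 nM, which is a limit of the assay and not a number. The exchange of bromo for iodo on an aromatic carbon, para to a large group, therefore matters in this series: the two steps that can be read are an at least 2.5-fold higher number from compound 2 to compound 3 (0.39 log units; beyond the scatter) and an at least 2.5-fold higher number from compound 1 to compound 3 (0.39 log units; beyond the scatter), and each lies beyond the scatter, with compound 3 the weaker inhibitor of growth in both comparisons. Among these compounds, compounds 1 and 2, level with each other, gave no sign of such a step, and the pair of steps now shows that the single exchange is enough to move the result, though only a lower bound on its size is known: the limit of > 50000 nM in this assay, at which 1 of the 3 values shown sits.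

As far as these compounds go, how far compound 3 really lies from the other two stays open, and so does whether the two exchanges, made at different places on the shared core, are equal in size. Also open, from the compounds shown here alone, is whether a chloro group, a methoxy group or a plain hydrogen at these places would read like iodo, like bromo or like neither.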